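Ring stereocentre inversion in a phosphoserine ester series

The source may hold more compounds than are shown below. What is called first, only, known or untested is meant among the compounds shown, and "the series" means these compounds.

Measured so far:
- compound 1, `CCCCCCCCCCCOc1ccccc1CCC(=O)OC[C@H]1OCCC[C@@H]1OP(=O)(O)OC[C@H](N)C(=O)O`: 5.3%
- compound 2, `N[C@@H](COP(=O)(O)OC[C@H]1OCCC[C@H]1OC(=O)CCc1ccccc1OCc1cccc(Oc2ccccc2)c1)C(=O)O`: 17.7%

In an assay on HEK293-A cells for agonist activity at probable G-protein coupled receptor 34 (Mus musculus), with a stated time of 1.5 h (a higher number here means a larger maximal response, a lower number a smaller maximal response), compound 1 gives 5.3%, the lowest of the two numbers. Compound 2 gives 17.7% in this assay, a number that sits beyond the usual scatter above compound 1. Among the compounds with values here, no step between measured compounds that differ in one place is available, so the two values show only that the pair differs by more than scatter.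

Compound 3, `CCCCCCCCCCCOc1ccccc1CCC(=O)OC[C@H]1OCCC[C@H]1OP(=O)(O)OC[C@H](N)C(=O)O`, is not yet measured. Its relation to compound 1: the two compounds have the same atoms and bonds; at least one stereo element is drawn with a configuration in one of them and without one in the other: 1 of 4 stereo elements differ; a stereocentre at a saturated ring carbon is drawn S in compound 1 and R in compound 3

Within the data shown here, no measured pair isolates the effect of this change. A maximal response near the floor can move either way on inversion of a single stereocentre; a step upward of modest size, within or just beyond the scatter, is expected, a number 6.7 percentage points higher from compound 1 to compound 3 (within the scatter). Compound 3 is expected to give about 12%, roughly between 2% and 30%.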

Compound 3, largest response reached (Emax), in percent of the reference or control that the assay uses: 5.2%
Beside the measured number, compound 3's estimate is 6.8 percentage points above it, within the range that was stated.
By their numbers in this assay, from the lowest: compounds 3 and 1 (each within the scatter of the next); then compound 2.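

In this assay, inversion of the stereocentre at a saturated ring carbon gives a number 0.1 percentage points lower from compound 1 to compound 3 (within the scatter). Within the data shown here, this is the first comparison that isolates a single change, and with this ester side chain in place the largest response does not distinguish the two configurations at this position. The comparison rests on one feature of the drawn structures: the fact that one of compounds 1 and 3 is drawn with a defined configuration and the other without, at the place where they differ.

Going by these compounds, whether the ring configuration has any bearing on the response with another ester side chain, such as that of compound 2, stays open. Also open, on these data alone, is whether an amide in place of the ester, or a longer chain on the aryl ether, would give a larger maximal response in this assay with either configuration.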